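The compounds below may be only part of what the source reports. "The series", "measured", "known", "first", "only" and "open" are said of these compounds alone.

Measured so far in a functional assay on HL-60 cells (Homo sapiens) for antiproliferative activity, read by MTT assay, with a stated time of 72 h (on this read-out lower numbers stand for stronger inhibition and higher numbers for weaker inhibition), for the series
- compound 1 `NC1=NC2(CCSCC2)N(OCCCOc2cccc(Cl)c2)C(N)=N1` at 260 nM
- compound 2 `NC1=NC2(CCSCC2)N(OCCCOc2cccc(Cl)c2Cl)C(N)=N1` at 30 nM
- compound 3 `NC1=NC2(CCOCC2)N(OCCCOc2cc(Cl)c(Cl)cc2Cl)C(N)=N1` at 2360 nM

Compound 2 has the lowest number of the three, and compound 1 and compound 3 both lie higher by more than the scatter. The next compound is compound 4 `NC1=NC2(CCSCC2)N(OCCCOc2ccccc2Cl)C(N)=N1` and the change from compound 2 is hydrogen in place of chloro on an aromatic carbon, taking 2,3-dichlorophenyl to 2-chlorophenyl.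

Going by the values given here, the one measured step that bears on this is an 8.7-fold lower number from compound 1 to compound 2 (0.94 log units; beyond the scatter) and it runs the opposite way, with chloro entering at a different aromatic carbon. Among the compounds with values here, compound 3 is joined to the others by no single change and gives no step. In this assay a higher number is therefore expected, of modest size and beyond the scatter, though the different carbon makes the transfer uncertain. The expected step is a 6.7-fold higher number from compound 2 to compound 4 (0.82 log units; beyond the scatter) as an estimate only. For compound 4 the estimated value is 200 nM with an expected range from 70 nM to 600 nM on these few data.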

Compound 4, half-maximal inhibitory concentration: 390 nM
Compound 4: the middle estimate sits 2.0-fold (0.29 log units) below what was measured, within the range that was stated.
By their numbers in this assay, from the lowest: compound 2; then compounds 1 and 4 (each within the scatter of the next); then compound 3.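

In this assay, taking the chloro off the 2,3-dichlorophenyl group gives a 13-fold higher number from compound 2 to compound 4 (1.11 log units; beyond the scatter), so the low number of compound 2 is now bracketed from both sides by a compound with a single chloro. Exchanging 3-chlorophenyl for 2-chlorophenyl gives a 1.5-fold higher number from compound 1 to compound 4 (0.18 log units; within the scatter), so the two single-chloro compounds stay within the scatter of each other, and among these three compounds only the pair of chloro groups together goes with the lower number. Nothing measured here accounts for this difference.

From the compounds shown here alone, whether chloro is specifically required at this aromatic carbon, ortho to a chloro group and meta to a large group, or whether methyl, methoxy or fluoro would serve there remains open. Also open, going by these compounds, is whether 2,3-dichlorophenyl keeps its number on the core of compound 3.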